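From Bromide to Cyanophenyl: Expected Solubility of Compound 3

This account rests on a few compounds, and the source may have more. Where it says the series, first, only, none or still open, it means among the compounds named here.

Compound 1, `Cc1cc(NCc2ccccn2)n2ncc(Br)c2n1`: 89300 nM
Compound 2, `COc1ccc(-c2c(C)nn3c(NCc4ccccn4)cc(C)nc23)cc1`: < 5000 nM

Among the measured compounds shown here, in a physicochemical assay for solubility, read by HPLC, using the shake flask method, measured as kinetic solubility, with a stated time of 2 h, at pH 7.4 (a higher number here means a more soluble compound, a lower number a less soluble compound), compound 1 gives 89300 nM, which is the only actual number among the values shown. Compound 2 sits at a limit of the assay, < 5000 nM, not a measured number (the limit of < 5000 nM in this assay, at which 1 of the 2 values shown sits). Compound 3, `Cc1cc(NCc2ccccn2)n2ncc(-c3ccc(C#N)cc3)c2n1`, is not yet measured; it differs from compound 1 by 4-cyanophenyl in place of bromo on an aromatic carbon. For the measured compounds named here, no measured pair isolates this change, so the direction rests on expectation alone: the estimated step of a 13-fold lower number from compound 1 to compound 3 (1.11 log units; beyond the scatter) is a decrease beyond the usual scatter. Compound 3 is therefore expected to give 7000 nM, within a range from 1500 nM to 35000 nM.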

Compound 3, solubility: < 5000 nM
Compound 3 ended at the assay's limit; the forecaster's own chance of this, stated with the estimate: 45%; at least 1.4-fold (0.14 log units) between middle value and limit.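

Among the compounds shown here, putting 4-cyanophenyl in place of bromo on this aromatic carbon gives, in this assay, the first measured pair that isolates this change: an at least 17-fold lower number from compound 1 to compound 3 (1.25 log units; beyond the scatter). Compound 3 stands at a limit of the assay, not at a number, so this step gives only a minimum size. Further drops at this position could not be told apart at that limit, which now holds most of the values: the limit of < 5000 nM in this assay, at which 2 of the 3 values shown sit.

On these data alone, how much of the step belongs to the phenyl ring and how much to the nitrile stays open. Also open, as far as these compounds go, is where a phenyl ring carrying an amine or a carboxylic acid at this carbon would fall.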